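The source may hold more compounds than are shown below. What is called first, only, known or untested is meant among the compounds shown, and "the series" means these compounds.

Measured compounds in the series:

Compound 1 `C=CC(=O)Nc1cc(Nc2ncc(Cl)c(Nc3ccccc3S(=O)(=O)C(C)C)n2)c(OC)cc1N1CCC(N2CCN(C)CC2)CC1`: in a functional assay on NCI-H3122 cells (Homo sapiens) for inhibition, read by CellTiter-Glo, with a stated time of 72 h (on this read-out lower numbers stand for stronger inhibition of growth and higher numbers for weaker inhibition of growth), compound 1 gives < 0.3 nM, a limit of the assay.
Compound 2 `C=CC(=O)Nc1cc(Nc2ncc(Cl)c(Nc3ccccc3S(=O)(=O)C(C)C)n2)c(OC)cc1N1CCN(S(C)(=O)=O)CC1`: in this assay compound 2 gives < 0.3 nM, a limit of the assay.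
Compound 3 `C=CC(=O)Nc1cc(Nc2ncc(Cl)c(Nc3ccccc3S(=O)(=O)C(C)C)n2)c(OC)cc1N1CCN(C)CC1`: in this assay compound 3 gives 33 nM.

Within the data shown here, compound 3 holds the only actual number in the set; the other two values sit at the limit of < 0.3 nM in this assay, at which 2 of the 3 values shown sit, and cannot be placed more closely. Among the measured compounds shown here, the one measured step, an at least 110-fold higher number from compound 2 to compound 3 (2.04 log units; beyond the scatter), concerns methyl in place of methylsulfonyl on an amine nitrogen in a ring, and its true size is open at the lower end since compound 2 sits at the limit.

Compound 4 `C=CC(=O)Nc1cc(Nc2ncc(Cl)c(Nc3ccccc3S(=O)(=O)C(C)C)n2)c(OC)cc1N1CCCN(C)CC1` differs from compound 3 by 4-methyl-1,4-diazepan-1-yl in place of 4-methylpiperazin-1-yl on an aromatic carbon. For the measured compounds named here, no measured step concerns a change of ring size, so the step from compound 2 to compound 3 bears on it only indirectly: it shows that the group at this aromatic carbon can move the number in this assay strongly, but not which way a ring expansion would go. The expectation is therefore a step of no more than modest size, a 1.3-fold lower number from compound 3 to compound 4 (0.12 log units; within the scatter), with the direction uncertain.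

Compound 4 is estimated at 25 nM in this assay, with a range of 6 nM to 100 nM.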

Compound 4, concentration for 50% growth inhibition: < 0.3 nM
Compound 4 ended at the assay's limit; the forecaster's own chance of this, stated with the estimate: 8%; middle value at least 83-fold (1.92 log units) from the limit.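

In this assay, 4-methyl-1,4-diazepan-1-yl in place of 4-methylpiperazin-1-yl on the aromatic carbon ortho to the (vinylcarbonyl)amino group gives an at least 110-fold lower number from compound 3 to compound 4 (2.04 log units; beyond the scatter), so a change of ring size alone, with the methyl on the ring nitrogen kept, moves the number strongly at this position. The earlier step changed only the group on the ring nitrogen, and compound 4 now shows that this methyl group does not by itself go with the higher number seen for compound 3. For compound 4 the value < 0.3 nM is a limit of the assay, and neither its step to compound 2 nor its place among the compounds at the limit can be read: the limit of < 0.3 nM in this assay, at which 3 of the 4 values shown sit.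

Open, from the compounds shown here alone, is whether the seven-membered ring keeps this effect with another group on its nitrogen, such as a hydrogen, an acetyl or a methylsulfonyl group. Also open, going by these compounds, is how far the six-membered ring tolerates small changes that leave the ring size as it is, such as a 3-methyl group on the piperazine or a longer chain than methyl on its nitrogen.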